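Lengthening the Side Chain of Compound 2

This account rests on a few compounds, and the source may have more. Where it says the series, first, only, none or still open, it means among the compounds named here.

Of the compounds shown here, two have been measured in a functional assay on the whole organism (stomach) for inhibition, with Rattus norvegicus as the target, at a dose of 100 mg/kg by the intraduodenal route; a lower number here means less inhibition, a higher number more inhibition at the dose given (going by the name of the read-out). Compound 1 `N=C(S)CCCn1nc(-c2ccccc2)ccc1=O` gives 75.6% in this assay. Compound 2 `Cc1ccc(=O)n(CC(=N)S)n1` gives 31.5% in this assay, the lower of the two numbers, a gap to compound 1 that lies beyond the scatter. Compound 3 `Cc1ccc(=O)n(CCC(=N)S)n1` has not yet been measured. It differs from compound 2 by a group of 4 heavy atoms (2 carbon, 1 nitrogen, 1 sulfur; no ring) in place of a group of 3 heavy atoms (1 carbon, 1 nitrogen, 1 sulfur; no ring), on a saturated chain carbon bound to an aromatic nitrogen. Within the data shown here, no step between measured compounds that differ in one place is available, so the expectation for compound 3 rests on the two values alone, and it leans upward partly because compound 1 gives 75.6% while differing from compound 2 in more than one place. The step is estimated as a number 13.5 percentage points higher from compound 2 to compound 3 (beyond the scatter), expected to reach only the edge of the scatter. Compound 3 is estimated at 45%, within a range from 20% to 70%.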

Compound 3, a percentage reported as inhibition, in the whole organism at one dose (the size of the read-out at that dose, not a potency): 73.9%
Compound 3: the middle estimate sits 28.9 percentage points below what was measured; the whole stated range lies below it.
By their numbers in this assay, from the lowest: compound 2; then compounds 3 and 1 (each within the scatter of the next).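

In this assay, the larger group, on a saturated chain carbon bound to an aromatic nitrogen, gives a number 42.4 percentage points higher from compound 2 to compound 3 (beyond the scatter), the first effect of a single change that can be read in this series. The position is therefore sensitive to the length of this side chain, even though the hydrogen-bond donor and acceptor counts are the same in the group that leaves and the group that enters. No measurement available here explains the size of this step.

The compounds shown leave open whether a longer chain at this place would carry the number further or lose it again. They also leave open whether the end of the chain needs its sulfur, or whether an amine or a carboxylic acid could stand there instead.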